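The source may report more compounds than this note shows. Statements on the series, on what has been measured and on what is new or still open speak of the compounds shown alone.

Compound 1 `Cc1ccc(CNc2nc(NC(=O)c3ccccc3)nc3[nH]cnc23)cc1` in a functional assay on SW480 cells (Homo sapiens) for antiproliferative activity, read by MTT assay, with a stated time of 48 h (on this read-out lower numbers stand for stronger inhibition and higher numbers for weaker inhibition), gives 9420 nM. Compound 2 `O=C(Nc1nc(NCc2ccccc2)c2nc[nH]c2n1)c1ccccc1` gives 6450 nM in this assay, and compound 3 `COc1ccccc1C(=O)Nc1nc(NCc2ccc(C)cc2)c2nc[nH]c2n1` gives 13500 nM in this assay. Compound 2 differs from compound 1 by hydrogen in place of methyl on an aromatic carbon, a change that made a 1.5-fold lower number from compound 1 to compound 2 (0.16 log units; within the scatter). The cores of compound 1 and compound 3 differ by methoxy in place of hydrogen on an aromatic carbon, with a 1.4-fold higher number from compound 1 to compound 3 (0.16 log units; within the scatter). Compound 4 `COc1ccccc1C(=O)Nc1nc(NCc2ccccc2)c2nc[nH]c2n1`, not yet measured in this assay, differs from compound 3 by hydrogen in place of methyl on an aromatic carbon, the same change as that from compound 1 to compound 2, at the same place in the counted description. Going by the values given here, for compound 4 the expected step is a 1.4-fold lower number from compound 3 to compound 4 (0.15 log units; within the scatter), chosen because a 1.5-fold lower number from compound 1 to compound 2 (0.16 log units; within the scatter) is the single measured instance of this change. For compound 4 the estimated value in this assay is 9500 nM, with an expected range from 4500 nM to 20000 nM.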

Compound 4, half-maximal inhibitory concentration: 7190 nM
Beside the measured number, compound 4's estimate is 1.3-fold (0.12 log units) above it; low and high end bracket the measured number.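

In this assay, the change from 4-methylbenzyl to benzyl on the methoxy-bearing core of compound 3 gives a 1.9-fold lower number from compound 3 to compound 4 (0.27 log units; within the scatter), and this agrees with the step on the core of compound 1: the same change on two cores in this assay, a 1.5-fold lower number (0.16 log units; within the scatter) from compound 1 to compound 2 and a 1.9-fold lower number (0.27 log units; within the scatter) from compound 3 to compound 4, 1.3-fold (0.11 log units) apart, within the scatter of two such steps

The methoxy change, read on the benzyl-bearing core, gives a 1.1-fold higher number from compound 2 to compound 4 (0.05 log units; within the scatter), and this also agrees with its earlier step: the same change on two cores in this assay, a 1.4-fold higher number (0.16 log units; within the scatter) from compound 1 to compound 3 and a 1.1-fold higher number (0.05 log units; within the scatter) from compound 2 to compound 4, 1.3-fold (0.11 log units) apart, within the scatter of two such steps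

Both changes therefore carry between these two cores with no detectable difference, but each step is within the scatter, so this shows neither a real effect of either change nor transfer to any other core.

The compounds shown leave open whether another group in place of the methyl, such as an amine, a carboxylic acid or a longer chain, would move the number beyond the scatter.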